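A few compounds are considered here, and "the series" means these few. Any claim that something is new, unique, unknown or untested is made for them only; others in the source may bear on it.

Measured in a functional assay on SW480 cells (Homo sapiens) for antiproliferative activity, read by MTT assay, with a stated time of 48 h; on this read-out higher numbers stand for weaker inhibition and lower numbers for stronger inhibition:
Compound 1 `CCCCCCC(CCO)n1cnc2c(OC)ncnc21`: > 50000 nM
Compound 2 `CCCCCCC(CCO)n1cnc2c(NC)ncnc21`: > 50000 nM
Compound 3 `CCCCCCC(CCO)n1cnc2cncnc21`: > 50000 nM

None of these three entries is a true number, as the evidence shows: the limit of > 50000 nM in this assay, at which 3 of the 3 values shown sit. Compound 2 stands at > 50000 nM, which is a limit of the assay. Its real potency is therefore unknown.

Compound 4 `CCCCCCCCC(CCO)n1cnc2c(NC)ncnc21` keeps the methylamino group of compound 2 and changes only the chain: ethyl in place of hydrogen on a saturated chain carbon, seven bonds along the chain from an aromatic nitrogen. This places ethyl where hydrogen stood, on a saturated chain carbon.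

Three measured steps exist, and all of them change a group on an aromatic carbon, not the chain. They are a step that the two limits leave unreadable from compound 1 to compound 2, a step that the two limits leave unreadable from compound 1 to compound 3 and a step that the two limits leave unreadable from compound 2 to compound 3. None of them has a size that can be read, and none touches the part of the structure that changes here. They offer no size to carry over, so any forecast must be cautious. A small move towards stronger inhibition is expected, and another limit result would be no surprise. The estimated change is an at least 1.1-fold lower number from compound 2 to compound 4 (0.04 log units; that floor lies within the scatter). For compound 4 the expected value is 45000 nM, with an estimated range from 15000 nM to 90000 nM.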

Compound 4, half-maximal inhibitory concentration: 3770 nM
Beside the measured number, compound 4's estimate is 12-fold (1.08 log units) above it; the measured number lies below the stated range.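

In this assay, the chain is the one part of the structure shown to move the read-out: ethyl in place of hydrogen on a saturated chain carbon, seven bonds along the chain from an aromatic nitrogen, gives an at least 13-fold lower number from compound 2 to compound 4 (1.12 log units; beyond the scatter). The earlier steps shown here, all of which change a group on an aromatic carbon, cannot be read, so they gave no size for any change to the structure, and compound 4 now gives the series a true number to compare against: the limit of > 50000 nM in this assay, at which 3 of the 4 values shown sit. Compound 2 stands at > 50000 nM, which is a limit, so the printed size of this step is a floor and not a full measure.

One step along the chain cannot show whether the read-out keeps falling as the chain grows, so a longer chain, or a chain ending in an amine or a carboxylic acid, remains an open test at this place. The compounds shown also leave open whether this longer chain would give a readable number with methoxy or hydrogen on the aromatic carbon in place of methylamino.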